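A few compounds are considered here, and "the series" means these few. Any claim that something is new, unique, unknown or untested is made for them only; others in the source may bear on it.

Of the compounds shown here, three have so far been measured in a functional assay on SW982 cells (Homo sapiens) for inhibition, read by MTT assay, with a stated time of 72 h; a higher number here means a weaker inhibitor, a lower number a stronger inhibitor. Compound 1 `COc1cc(OC)c(OC)cc1/C=C/C(=O)c1ccc(C)cc1` gives 81100 nM in this assay. Compound 2 `COc1cc(OC)c(OC)cc1/C=C/C(=O)c1cc(Cc2ccccc2)cc(Cc2ccccc2)c1` gives 69900 nM in this assay, and the numbers of compound 1 and compound 2 lie within the scatter of each other. For compound 3 `COc1cc(OC)c(-c2cc(=O)c3cc(O)ccc3o2)cc1OC` this assay reports only a limit, > 150000 nM, namely (the limit of > 150000 nM in this assay, at which 1 of the 3 values shown sits). Compound 4 `COc1cc(OC)c(OC)cc1/C=C/C(=O)c1ccc(Cl)cc1` has not yet been measured. It differs from compound 1 in one place: chloro in place of methyl on an aromatic carbon. Among the measured compounds shown here, no measured pair shows this change, so its effect is open. The expected step, a 1.4-fold lower number from compound 1 to compound 4 (0.13 log units; within the scatter), is small and lies within the usual scatter. The estimate for compound 4 in this assay is therefore 60000 nM, with a range from 25000 nM to 150000 nM.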

Compound 4, half-maximal inhibitory concentration: 58500 nM
Beside the measured number, compound 4's estimate is 1.0-fold (0.01 log units) above it; the measured number falls inside the stated range.
By their numbers in this assay, from the lowest: compounds 4, 2 and 1 (each within the scatter of the next). At a limit, above all of these: compound 3.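

Chloro in place of methyl, 4-methylphenyl to 4-chlorophenyl, gives the first measured step at this position, on an aromatic carbon para to a large group: in this assay the change gives a 1.4-fold lower number from compound 1 to compound 4 (0.14 log units; within the scatter) and no more. The two groups therefore cannot be told apart at this position in this assay. Nothing measured here offers a reason for this step.

As far as these compounds go, whether an amine, a carboxylic acid or a longer chain at the same position would move the number beyond the scatter remains open.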